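Removing One Chloro from the Amide Aryl Ring

The source may report more compounds than this note shows. Statements on the series, on what has been measured and on what is new or still open speak of the compounds shown alone.

Compound 1 `O=C(Nc1ccc(Cl)c(-c2nnc3c(Cl)cccn23)c1)c1ccc(Cl)cc1` and compound 2 `O=C(Nc1ccc(Cl)c(-c2nnc3c(Cl)cccn23)c1)c1ccc(Cl)cc1Cl` share one core and differ only on the aryl amide, where compound 2 carries chloro in place of hydrogen on an aromatic carbon. In a functional assay on T47D cells (Homo sapiens) for antiproliferative activity, read by MTT assay, with a stated time of 72 h (on this read-out higher numbers stand for weaker inhibition and lower numbers for stronger inhibition), compound 1 gives > 100000 nM, which is a limit of the assay and not a number. In this assay compound 2 gives > 100000 nM, again a limit. The step that the two limits leave unreadable from compound 1 to compound 2 therefore cannot be read, and compound 2 stands at the ceiling of what has been recorded, together with compound 1 (the limit of > 100000 nM in this assay, at which 2 of the 2 values shown sit).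

Compound 3 `O=C(Nc1ccc(Cl)c(-c2nnc3c(Cl)cccn23)c1)c1ccccc1Cl` is reached from compound 2 by the change (hydrogen in place of chloro on an aromatic carbon); read one bond further out, 2,4-dichlorophenyl becomes 2-chlorophenyl. For the measured compounds named here, only the step from compound 1 to compound 2 bears on this change, and its size is not readable. Going by the values given here, no measured step therefore sets a direction for compound 3 in this assay, and the expectation is that compound 3 stays at or near the limit. Compound 3 is estimated at 100000 nM, within 30000 nM to 300000 nM. The step of a number no higher from compound 2 to compound 3 (the limit leaves the size open) is expected to be small.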

Compound 3, half-maximal inhibitory concentration: 83800 nM
The estimate for compound 3 lay 1.2-fold (0.08 log units) above the measured number; measured number inside the range.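

In this assay, for the compounds shown here, compound 3 gives a number where the earlier compounds gave only limits, so the 2-chlorophenyl amide provides the first value that can be placed on the scale. Taking away the chloro that is para to a large group gives an at least 1.1-fold lower number from compound 2 to compound 3 (0.07 log units; that floor lies within the scatter), and the comparison of the 2-chlorophenyl amide with the 4-chlorophenyl amide gives an at least 1.1-fold lower number from compound 1 to compound 3 (0.07 log units; that floor lies within the scatter), so neither the loss of this chloro nor the shift between the two chlorophenyl amides can yet be said to matter beyond the scatter. Compound 1 and compound 2 each stand only at a limit of the assay, so the real size of both steps stays open: the limit of > 100000 nM in this assay, at which 2 of the 3 values shown sit.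

The compounds shown leave open whether any group at this position can move the number clearly, as the only substituents seen on this ring are chloro and hydrogen. It also remains to be seen how an amine or a carboxylic acid in place of hydrogen here, or a methoxy group in place of the remaining chloro, would read in this assay.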